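The compounds below may be only part of what the source reports. "The series", "measured", "known", "first", "only" and "open" are said of these compounds alone.

In a functional assay on MCF7 cells (Homo sapiens) for inhibition, read by sulforhodamine B assay (on this read-out lower numbers stand for stronger inhibition and higher numbers for weaker inhibition), the three measured compounds give the following numbers:

compound 1 `O=C1C(Nc2ccc(I)cc2)=CC(=O)c2c1nc1n2[C@H]2OC[C@@H](O)[C@H]2OC1`: 3890 nM
compound 2 `CCCc1ccc(NC2=CC(=O)c3nc4n(c3C2=O)[C@H]2OC[C@@H](O)[C@H]2OC4)cc1`: 4660 nM
compound 3 `O=C1C=C(Nc2ccccc2F)C(=O)c2c1nc1n2[C@H]2OC[C@@H](O)[C@H]2OC1`: 3640 nM

Compound 1 stands second highest of the three, but all three numbers lie within the scatter of one another, so no order among them can be read. For the measured compounds named here, the only single-point step in this set, a 1.3-fold lower number from compound 2 to compound 3 (0.11 log units; within the scatter), swaps one aryl group for another on the amine nitrogen and changes nothing beyond the scatter.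

Compound 4 `O=C1C(N2CCCCC2)=CC(=O)c2c1nc1n2[C@H]2OC[C@@H](O)[C@H]2OC1` is not yet measured in this assay. It differs from compound 1 as follows: piperidin-1-yl in place of (4-iodophenyl)amino on a double-bonded ring carbon. Every measured compound carries an aryl amino group on this double-bonded ring carbon; compound 4 instead carries piperidin-1-yl, a non-aromatic ring bound directly through its nitrogen. Going by the values given here, no measured step covers a change of this kind, so the step of a 1.3-fold lower number from compound 2 to compound 3 (0.11 log units; within the scatter) bears on it only indirectly, showing that the aryl part can be varied without effect beyond the scatter. Whether removing the aryl amino group altogether moves the number is not known from these data. Compound 4 is therefore estimated at 6500 nM with a range of 2500 nM to 20000 nM, which means an expected step of a 1.7-fold higher number from compound 1 to compound 4 (0.22 log units; within the scatter), wide enough to admit a number within the scatter of compound 1 or a somewhat higher one.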

Compound 4, half-maximal inhibitory concentration: > 8000 nM
Compound 4 gave a limit, no number; the forecaster's own chance of this, stated with the estimate: 10%; at least 1.2-fold (0.09 log units) between middle value and limit.
By their numbers in this assay, from the lowest: compounds 3, 1 and 2 (each within the scatter of the next). At a limit, above all of these: compound 4.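

In this assay, piperidin-1-yl in place of (4-iodophenyl)amino on the double-bonded ring carbon gives an at least 2.0-fold higher number from compound 1 to compound 4 (0.31 log units; beyond the scatter), the only step shown that lies beyond the scatter. The value for compound 4 is a limit and not a number, so the true size of this step stays unfixed: the limit of > 8000 nM in this assay, at which 1 of the 4 values shown sits. Varying the aryl part alone gave a 1.3-fold lower number from compound 2 to compound 3 (0.11 log units; within the scatter), and in this assay compounds 1, 2 and 3, all aryl amino compounds, stay within the scatter of one another, so this position now shows a difference between those aryl amino groups and a ring bound directly through its nitrogen, with no listed compound going against that reading.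

The step takes away the aromatic ring and the amine hydrogen together, so the compounds shown do not tell which of the two goes with the higher reading. A cyclohexylamino group, which keeps the amine hydrogen without the aromatic ring, and an N-methyl-N-phenylamino group, which keeps the aromatic ring without that hydrogen, would separate the two.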